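Working notes: compound 3 to compound 4

A few compounds are considered here, and "the series" means these few. Any claim that something is new, unique, unknown or untested is made for them only; others in the source may bear on it.

- compound 1 `COc1ncc(-c2ccc3nc(NC(=O)N4CCCC4)nn3c2)cc1NS(=O)(=O)c1ccc(F)cc1`: 1690 nM
- compound 2 `COc1ncc(-c2ccc3nc(NC(=O)NCC(=O)N4CCCC4)nn3c2)cc1NS(=O)(=O)c1ccc(F)cc1`: 1000 nM
- compound 3 `COc1ncc(-c2ccc3nc(NC(=O)NCCN4CCN(C)CC4)nn3c2)cc1NS(=O)(=O)c1ccc(F)cc1`: 760 nM

All three values come from a functional assay on U-87MG ATCC cells for cytotoxicity against U-87 MG (Homo sapiens), read by MTT assay, with a stated time of 72 h; on this read-out lower numbers stand for stronger inhibition and higher numbers for weaker inhibition. Two steps fix the standing of the third entry. There is a 2.2-fold lower number from compound 1 to compound 3 (0.35 log units; beyond the scatter), and there is a 1.3-fold lower number from compound 2 to compound 3 (0.12 log units; within the scatter).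

The next change leads to compound 4 `CNC(=O)Nc1nc2ccc(-c3cnc(OC)c(NS(=O)(=O)c4ccc(F)cc4)c3)cn2n1`: hydrogen in place of (4-methylpiperazin-1-yl)methyl on a saturated chain carbon bound to an amide-type nitrogen. In words, this is hydrogen in place of (4-methylpiperazin-1-yl)methyl on a saturated chain carbon bound to an amide-type nitrogen, or 2-(4-methylpiperazin-1-yl)ethyl to methyl.

Among the measured compounds shown here, no measured step makes this exact change. The closest guide is a 2.2-fold lower number from compound 1 to compound 3 (0.35 log units; beyond the scatter), which is modest, while a 1.7-fold lower number from compound 1 to compound 2 (0.23 log units; within the scatter) shows little movement. Compound 4 loses the chain, so a modest move back towards the number of compound 1 is expected in this assay, with a return to within the scatter quite possible. The expected change is a 1.8-fold higher number from compound 3 to compound 4 (0.27 log units; within the scatter). For compound 4 the estimated value is 1400 nM, with an expected range of 600 nM to 3500 nM.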

Compound 4, half-maximal inhibitory concentration: 640 nM
For compound 4 the middle estimate is 2.2-fold (0.34 log units) above the measured one, and the stated range covers the measured number.
By their numbers in this assay, from the lowest: compounds 4, 3, 2 and 1 (each within the scatter of the next, the first and the last beyond it).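

In this assay, hydrogen in place of (4-methylpiperazin-1-yl)methyl on a saturated chain carbon bound to an amide-type nitrogen leaves the number unresolved (a 1.2-fold lower number from compound 3 to compound 4 (0.07 log units; within the scatter)), and the replacement of (pyrrolidin-1-yl)carbonyl at the same place reads the same way (a 1.6-fold lower number from compound 2 to compound 4 (0.19 log units; within the scatter)). Neither six-membered ring nor carbonyl-bearing chain is therefore needed to hold this level, and methylamino in place of pyrrolidin-1-yl on a carbonyl carbon is enough for a step beyond the scatter (a 2.6-fold lower number from compound 1 to compound 4 (0.42 log units; beyond the scatter)). No available evidence bears on the reason for this result.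

Left open is whether ethyl or 2-hydroxyethyl in place of methyl would shift the number beyond the scatter. Also open, on these data alone, is how a plain amino group would read at this place.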